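Ethyl to propyl on the amide: permeability notes

A few compounds are considered here, and "the series" means these few. Any claim that something is new, unique, unknown or untested is made for them only; others in the source may bear on it.

Among the compounds with values here, compound 2 `CCNC(=O)c1cc(C(=O)NC)nn1[C@@H](C)c1ccccc1` stands highest of the two numbers so far in an ADME assay for permeability (a higher number here means that the compound crosses the layer faster, a lower number that the compound crosses the layer more slowly), where compound 2 gives 435 nm/s. Within the data shown here, its only measured neighbour is compound 1 `CNC(=O)c1cc(C(=O)N[C@H]2[C@@H]3C[C@@H](O)C[C@@H]32)n([C@@H](C)c2ccccc2)n1`, which in this assay gives 61 nm/s; the step of a 7.1-fold higher number from compound 1 to compound 2 (0.85 log units; beyond the scatter) came with a group of 2 heavy atoms in place of a group of 7 heavy atoms on an amide-type nitrogen.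

Compound 3 `CCCNC(=O)c1cc(C(=O)NC)nn1[C@@H](C)c1ccccc1` is not yet measured. It differs from compound 2 by methyl in place of hydrogen on a saturated chain carbon, two bonds along the chain from an amide-type nitrogen, read one bond further out as ethylamino to propylamino. Among the measured compounds shown here, the single measured step, a 7.1-fold higher number from compound 1 to compound 2 (0.85 log units; beyond the scatter), bears on it only loosely: it also changed the group on that amide-type nitrogen, but it exchanged a group of 7 heavy atoms for a group of 2, so its size is no guide to one added methyl. For the measured compounds named here, no measured pair shows methyl to ethyl or ethyl to propyl on its own. The step expected in this assay is therefore small, likely within the scatter or a slight rise, a 1.2-fold higher number from compound 2 to compound 3 (0.08 log units; within the scatter). For compound 3 the estimate is 520 nm/s, with a range of 290 nm/s to 850 nm/s.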

Compound 3, apparent permeability: 560 nm/s
Estimate against measurement, compound 3: 1.1-fold (0.03 log units) below; the measured number falls inside the stated range.
By their numbers in this assay, from the lowest: compound 1; then compounds 2 and 3 (each within the scatter of the next).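

In this assay, within the data shown here, compound 3 and compound 2 form the first pair that isolates one added methyl on a saturated chain carbon, two bonds along the chain from an amide-type nitrogen, and the result is a 1.3-fold higher number from compound 2 to compound 3 (0.11 log units; within the scatter): on these numbers, ethylamino and propylamino cannot be told apart. The larger exchange on that amide-type nitrogen now has two readings, a 7.1-fold higher number from compound 1 to compound 2 (0.85 log units; beyond the scatter) and a 9.2-fold higher number from compound 1 to compound 3 (0.96 log units; beyond the scatter), both beyond the scatter, so compound 2 and compound 3 each stand apart from compound 1 while the chain extension itself does not separate them. No supporting measurement bears on the reason for these numbers.

Still open, on these data alone, is whether a longer chain such as butyl, or a branched chain such as isopropyl, on that amide-type nitrogen would stay level with compound 2 and compound 3 in this assay or move clear of the scatter. Also open is what an amine or a carboxylic acid at the end of the propyl chain would give in the same read-out, since every chain shown here carries only carbon and hydrogen.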